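The source may report more compounds than this note shows. Statements on the series, on what has been measured and on what is new or still open speak of the compounds shown alone.

Compound 1 `O=C(Nc1ccc[n+]([O-])c1)c1cc2cnc(Nc3ccc(N4CCNCC4)cn3)nc2n1C1CCCC1`: 125000 nM
Compound 2 `O=C(Nc1ccccc1)c1cc2cnc(Nc3ccc(N4CCNCC4)cn3)nc2n1Cc1ccccc1`: 3600 nM

Going by the values given here, both values come from a functional assay on MIA PaCa-2 cells (Homo sapiens) for inhibition, read by MTT assay (on this read-out lower numbers stand for stronger inhibition and higher numbers for weaker inhibition), and are the only numbers so far. Compound 1 stands at the top of this short range: at 125000 nM it has the higher number of the two and is the weaker inhibitor. Compound 2 gives 3600 nM and lies below it by a gap well beyond the usual scatter of repeated measurements.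

Compound 3 `O=C(Nc1ccccc1C(F)(F)F)c1cc2cnc(Nc3ccc(N4CCNCC4)cn3)nc2n1C1CCCC1` keeps the core of compound 1 and changes one group on the amide-type nitrogen, where a 2-(trifluoromethyl)phenyl group enters: a group of 10 heavy atoms (7 carbon, 3 fluorine; one six-membered aromatic ring of carbon only) in place of a group of 7 heavy atoms (5 carbon, 1 nitrogen, 1 oxygen; one six-membered aromatic ring with 1 hetero atom), on an amide-type nitrogen (the change). Among the compounds with values here, no measured pair shows this change alone, so any expectation remains loose. A large step towards stronger inhibition in this assay is expected, because compound 2 at 3600 nM shows that a much lower number is reachable with the shared core. The expected size of the move is a 21-fold lower number from compound 1 to compound 3 (1.32 log units; beyond the scatter) (an estimate). For compound 3 the estimated value is 6000 nM (expected range 1500 nM to 25000 nM).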

Compound 3, half-maximal inhibitory concentration: 3160 nM
Compound 3: the middle estimate sits 1.9-fold (0.28 log units) above what was measured; the range from low to high includes it.
By their numbers in this assay, from the lowest: compounds 3 and 2 (each within the scatter of the next); then compound 1.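

Compound 1 and compound 3 share their core and differ only in the group on the amide-type nitrogen, and in this assay that single exchange gives a 40-fold lower number from compound 1 to compound 3 (1.60 log units; beyond the scatter). This is the only pair shown that differs in one place, so it shows that this position alone can carry a large change in the read-out, something compound 2 could not show, as it also differs from compound 1 in a second group on the core. Nothing measured here bears on why the number falls, and the exchange replaces a ring holding nitrogen and oxygen with a carbon-only ring carrying trifluoromethyl, all in one step.

Still open, from the compounds shown here alone, is how much of the step belongs to the change of ring and how much to the trifluoromethyl group, which a plain pyridine ring without the oxygen of compound 1, or a methoxy group or chlorine in place of trifluoromethyl, could begin to separate. Also open, going by these compounds, is whether the same exchange gives a step of similar size when the cyclopentyl group on the core is replaced by another group, such as a short ethyl chain.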